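Removing One Chloro Group from a Dichlorophenyl Ring

This account rests on a few compounds, and the source may have more. Where it says the series, first, only, none or still open, it means among the compounds named here.

Compound 1, `C=CCn1c(=O)/c(=C\c2ccccc2Cl)[nH]c(=O)/c1=C\c1ccccc1OC`: 5100 nM
Compound 2, `C=CCn1c(=O)/c(=C\c2cccc(Cl)c2Cl)[nH]c(=O)/c1=C\c1ccccc1OC`: 1600 nM
Compound 3, `COc1ccccc1/C=c1\c(=O)[nH]/c(=C/c2cccc(Cl)c2Cl)c(=O)n1C`: 200 nM

These three compounds were tested in a functional assay on HeLa cells (Homo sapiens) for cytotoxicity, read by CCK-8 assay, with a stated time of 72 h; on this read-out lower numbers stand for stronger inhibition and higher numbers for weaker inhibition. Compound 3 gives the lowest number of the three, and its steps to both others lie beyond the scatter. The core of compound 3 differs from that of compound 2 by hydrogen in place of vinyl on a saturated chain carbon bound to an aromatic nitrogen, and this change made an 8.0-fold lower number from compound 2 to compound 3 (0.90 log units; beyond the scatter). Compound 1 differs from compound 2 by hydrogen in place of chloro on an aromatic carbon, a change that made a 3.2-fold higher number from compound 2 to compound 1 (0.50 log units; beyond the scatter). Compound 4, `COc1ccccc1/C=c1\c(=O)[nH]/c(=C/c2ccccc2Cl)c(=O)n1C`, is the unmeasured partner of compound 3 carrying the same change, (hydrogen in place of chloro on an aromatic carbon). Because a 3.2-fold higher number from compound 2 to compound 1 (0.50 log units; beyond the scatter) was a modest loss on the other core, a loss of similar size is expected here, so a 3.2-fold higher number from compound 3 to compound 4 (0.51 log units; beyond the scatter) is the estimated step. Compound 4 is therefore expected to give about 640 nM, most likely between 300 nM and 1500 nM.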

Compound 4, half-maximal inhibitory concentration: 300 nM
The estimate for compound 4 lay 2.1-fold (0.33 log units) above the measured number, and the stated range covers the measured number.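

In this assay, the step from 2,3-dichlorophenyl to 2-chlorophenyl on the core of compound 3 is a 1.5-fold higher number from compound 3 to compound 4 (0.18 log units; within the scatter), and this change does not measurably differ between the two cores: the same change on two cores in this assay, a 3.2-fold higher number (0.50 log units; beyond the scatter) from compound 2 to compound 1 and a 1.5-fold higher number (0.18 log units; within the scatter) from compound 3 to compound 4, 2.1-fold (0.33 log units) apart, within the scatter of two such steps. The other change also carries over, here as a 17-fold lower number from compound 1 to compound 4 (1.23 log units; beyond the scatter), and again the two cores do not measurably differ: the same change on two cores in this assay, an 8.0-fold lower number (0.90 log units; beyond the scatter) from compound 2 to compound 3 and a 17-fold lower number (1.23 log units; beyond the scatter) from compound 1 to compound 4, 2.1-fold (0.33 log units) apart, within the scatter of two such steps. These two pairs show that each change behaved similarly across these four compounds, but they cannot show that it would do so on any other core, and the chloro step lies beyond the scatter on one core and within it on the other.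

From the compounds shown here alone, it remains open how a bromo group or a nitrile would compare with the chloro group removed here, and how a longer chain, such as propyl, would compare with the methyl group of compound 3.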